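A few compounds are considered here, and "the series" means these few. Any claim that something is new, unique, unknown or untested is made for them only; others in the source may bear on it.

Compound 1 `CC(C)N(Cc1cccc(OCCCCCC(=O)O)c1)C(=O)c1ccc(-c2ccc3c(c2)OCCO3)cc1`: in an ADME assay on HEK293 cells (Homo sapiens) for cytotoxicity, read by CellTiter-Glo and resazurin assay, with a stated time of 72 h (on this read-out higher numbers stand for an effect only at larger amounts of compound and lower numbers for an effect already at smaller amounts), compound 1 gives no number but only a limit of the assay, > 21900 nM.
Compound 2 `CC(C)N(Cc1cccc(OCCCCCC(=O)O)c1)C(=O)c1ccc(-c2ccc3cc[nH]c3c2)cc1`: in this assay compound 2 likewise gives only a limit, > 26000 nM.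
Compound 3 `CCOC(=O)CCCCCOc1cccc(CN(C(=O)c2ccc(-c3ccc4c(c3)OCCO4)cc2)C(C)C)c1`: in this assay compound 3 again gives only a limit, > 24400 nM.

None of the three measured compounds produced a number in this assay; each result sits at a limit, as shown by the limit of > 21900 nM in this assay, at which 1 of the 3 values shown sits, the limit of > 24400 nM in this assay, at which 1 of the 3 values shown sits, and (the limit of > 26000 nM in this assay, at which 1 of the 3 values shown sits). With every value at a limit, the steps between the compounds stay unreadable: a step that the two limits leave unreadable from compound 1 to compound 2, and a step that the two limits leave unreadable from compound 1 to compound 3.

Compound 4 `CCOC(=O)CCCCCOc1cccc(CN(C(=O)c2ccc(-c3ccc4cc[nH]c4c3)cc2)C(C)C)c1` has not yet been measured. Compared with compound 3 it carries 1H-indol-6-yl in place of 2,3-dihydro-1,4-benzodioxin-6-yl on an aromatic carbon. The same change separates compound 1 from compound 2, where it reads (1H-indol-6-yl in place of 2,3-dihydro-1,4-benzodioxin-6-yl on an aromatic carbon); both times the change sits at the same place, so the two cases are the same change on two different cores. The two cores themselves differ in that compound 3 carries ethyl in place of hydrogen on an oxygen next to a carbonyl group relative to compound 1.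

The step expected from compound 3 to compound 4 is a step that the limit leaves unreadable from compound 3 to compound 4, and this rests on the unreadable step that the two limits leave unreadable from compound 1 to compound 2 together with compound 3 sitting at a limit of > 24400 nM. Compound 4 is therefore expected to give about 25000 nM, within 12000 nM to 60000 nM, most likely again as a limit rather than a number.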

Compound 4, half-maximal effective concentration: > 26000 nM
Compound 4: a limit, no number (the forecaster's own chance of this, stated with the estimate: 85%); at least 1.0-fold (0.01 log units) between middle value and limit.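

Compound 4 gives only a limit in this assay, as do compound 1, compound 2 and compound 3, and neither its step from compound 3 nor its step from compound 2 can be read. The compounds shown leave open how the change to 1H-indol-6-yl or the added ethyl would alter the effect on these cells, since none of the four gives a number.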